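The source may hold more compounds than are shown below. What is called first, only, known or untested is meant among the compounds shown, and "the series" means these compounds.

Values measured in an ADME assay on MT4 cells (Homo sapiens) for cytotoxicity, read by MTT assay (on this read-out higher numbers stand for lower toxicity in this test and lower numbers for higher toxicity in this test), so far:
Compound 1 `CN1C(=O)c2ccccc2C(C(=O)NCc2ccc(F)cc2)C1=O` gives > 250000 nM as a limit of the assay, not a number
Compound 2 `O=C(Nc1cccc(F)c1)C1C(=O)N(O)C(=O)c2ccccc21` gives 64000 nM
Compound 3 `O=C(NCc1ccccc1)C1C(=O)N(O)C(=O)c2ccccc21` gives 130000 nM

Compound 3 gives 130000 nM as the highest of the two true numbers here. Compound 4 `O=C(NCc1ccc(O)c(O)c1)C1C(=O)N(O)C(=O)c2ccccc21` carries 3,4-dihydroxyphenyl in place of phenyl on a saturated chain carbon bound to an amide-type nitrogen. Within the data shown here, the only measured step, a 2.0-fold higher number from compound 2 to compound 3 (0.31 log units; beyond the scatter) and modest in size, changes a different group, so it offers only a rough guide. A similarly modest step is therefore expected in this assay toward a lower number, since compound 3 with 130000 nM already stands highest among the true numbers. The expected step is modest (a 2.2-fold lower number from compound 3 to compound 4 (0.34 log units; beyond the scatter)). For compound 4 the estimated value is 60000 nM (expected range 18000 nM to 150000 nM).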

Compound 4, half-maximal cytotoxic concentration: 11000 nM
The estimate for compound 4 lay 5.5-fold (0.74 log units) above the measured number, and the stated range ends above it.
By their numbers in this assay, from the lowest: compound 4; then compound 2; then compound 3. At a limit, above all of these: compound 1.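

Placing 3,4-dihydroxyphenyl in place of phenyl on a saturated chain carbon bound to an amide-type nitrogen gives a 12-fold lower number from compound 3 to compound 4 (1.07 log units; beyond the scatter) in this assay. This position therefore responds strongly to what the ring carries, far more than the earlier change at the amide-type nitrogen suggested, a 2.0-fold higher number from compound 2 to compound 3 (0.31 log units; beyond the scatter). Nothing measured here explains why.

The compounds shown leave open whether both hydroxyl groups are needed for this drop. They also leave open how a single hydroxyl, a methoxy group or an amine on that ring would behave.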